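This account rests on a few compounds, and the source may have more. Where it says the series, first, only, none or still open, it means among the compounds named here.

In a functional assay on U-373MG ATCC cells (Homo sapiens) for inhibition, read by MTT assay, with a stated time of 72 h (on this read-out lower numbers stand for stronger inhibition of growth and higher numbers for weaker inhibition of growth), compound 1 `CC(C)[Si]1(C(C)C)OC[C@H]2O[C@@H](n3ccc(=O)[nH]c3=O)[C@H](O)[C@@H]2O[Si](C(C)C)(C(C)C)O1` gives 81000 nM and compound 2 `Cc1cn([C@@H]2O[C@@H]3CO[Si](C(C)C)(C(C)C)O[Si](C(C)C)(C(C)C)O[C@H]3[C@H]2O)c(=O)[nH]c1=O` gives 87000 nM. Compound 3 `Cc1cn([C@@H]2O[C@H](CO[Si](c3ccccc3)(c3ccccc3)C(C)(C)C)[C@@H](O)[C@H]2O)c(=O)[nH]c1=O` gives 25000 nM, the lowest of the three numbers and beyond the scatter from both others. Compound 4 `CC(C)(C)[Si](OC[C@H]1O[C@@H](n2ccc(N)nc2=O)[C@H](O)[C@@H]1O)(c1ccccc1)c1ccccc1` differs from compound 3 in one place: a group of 8 heavy atoms (4 carbon, 3 nitrogen, 1 oxygen; one six-membered aromatic ring with 2 hetero atoms) in place of a group of 9 heavy atoms (5 carbon, 2 nitrogen, 2 oxygen; one six-membered aromatic ring with 2 hetero atoms), on a saturated ring carbon. The change sits on a saturated ring carbon, next to the ring oxygen. For the measured compounds named here, only one measured step bears on this group: a 1.1-fold higher number from compound 1 to compound 2 (0.03 log units; within the scatter), methyl in place of hydrogen on an aromatic carbon, and it stays within the scatter. That step covers only part of the exchange, so the expectation in this assay is weakly grounded, and no shift beyond the scatter is expected. The expected step is a 1.3-fold lower number from compound 3 to compound 4 (0.10 log units; within the scatter). For compound 4 the estimated value is 20000 nM, with an expected range of 7000 nM to 60000 nM.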

Compound 4, concentration for 50% growth inhibition: 28000 nM
The estimate for compound 4 lay 1.4-fold (0.15 log units) below the measured number; measured number inside the range.
By their numbers in this assay, from the lowest: compounds 3 and 4 (each within the scatter of the next); then compounds 1 and 2 (each within the scatter of the next).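

In this assay, replacing the whole group on the saturated ring carbon, next to the ring oxygen, gives a 1.1-fold higher number from compound 3 to compound 4 (0.05 log units; within the scatter). The earlier step covered only a methyl in place of hydrogen on an aromatic carbon, whereas this one exchanges the group of 9 heavy atoms for the group of 8 heavy atoms and still stays within the scatter. No measurement shown accounts for this result. Going by these compounds, it remains open whether a carboxylic acid or a longer chain on that aromatic ring would shift the number beyond the scatter.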